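The compounds below may be only part of what the source reports. "The series", "measured", "known", "first", "only" and "open" are said of these compounds alone.

In an ADME assay on Vero cells (Chlorocebus sabaeus) for cytotoxicity, read by MTT assay, with a stated time of 72 h (a lower number here means that less compound is tolerated, a higher number that more compound is tolerated), compound 1 (`COc1ccc(/C=C(\C)C(=O)/C=C/c2ccc(F)cc2)cc1`) gives 68100 nM and holds the higher of the two numbers at hand. Compound 2 (`CC/C(=C\c1ccc(Cl)cc1)C(=O)/C=C/c1ccc(Br)cc1`) gives 29400 nM as the lower number, a gap beyond the usual scatter. Compound 3 (`COc1ccc(/C=C(\C)C(=O)/C=C/c2ccccc2F)cc1`) awaits measurement and differs from compound 1 by 2-fluorophenyl in place of 4-fluorophenyl on a double-bonded chain carbon bound to a double-bonded chain carbon with 2-fluorophenyl in place of 4-fluorophenyl on a double-bonded chain carbon bound to a double-bonded chain carbon. Among the measured compounds shown here, no measured pair shows this change, and in this assay no step beyond the scatter is expected in either direction. The expected step is a 1.1-fold lower number from compound 1 to compound 3 (0.05 log units; within the scatter) and stays within the scatter. Compound 3 is estimated at 60000 nM with 25000 nM to 140000 nM as the expected range.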

Compound 3, half-maximal cytotoxic concentration: 81200 nM
For compound 3 the middle estimate is 1.4-fold (0.13 log units) below the measured one; the measured number falls inside the stated range.
By their numbers in this assay, from the lowest: compound 2; then compounds 1 and 3 (each within the scatter of the next).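

In this assay, 2-fluorophenyl in place of 4-fluorophenyl on a double-bonded chain carbon bound to a double-bonded chain carbon gives a 1.2-fold higher number from compound 1 to compound 3 (0.08 log units; within the scatter), so this read-out does not tell the two fluorophenyl groups apart at this place. This is the first pair shown that differs in one place, which compounds 1 and 2 alone could not offer. Nothing at hand offers an explanation for this result.

From the compounds shown here alone, whether an amine or a carboxylic acid in place of the fluorine would move the number beyond the scatter remains open. So does whether the same change would give a similar step on the core of compound 2.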